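Swapping an ortho group on a weakly cytotoxic urea

This account rests on a few compounds, and the source may have more. Where it says the series, first, only, none or still open, it means among the compounds named here.

compound 1 `CSc1ccccc1NC(=O)N[C@H]1CC[C@H](Oc2ccc(F)cc2)CC1`: > 20000 nM
compound 2 `COc1cccc(NC(=O)N[C@H]2CC[C@H](Oc3ccc(F)cc3)CC2)c1`: 14000 nM
compound 3 `O=C(Nc1cccc(Br)c1)N[C@H]1CC[C@H](Oc2ccc(F)cc2)CC1`: 6200 nM

In a functional assay on CRL2813 cells (Homo sapiens) for cytotoxicity, read by sulforhodamine B assay, with a stated time of 5 days (on this read-out lower numbers stand for stronger inhibition and higher numbers for weaker inhibition), compound 1 gives only > 20000 nM, which is a limit of the assay and not a number. It stands at the limit of > 20000 nM in this assay, at which 1 of the 3 values shown sits, so compound 1 is the weakest of the three measured ureas in any reading of the data. Compound 2 gives 14000 nM in this assay, and compound 3 gives 6200 nM. The step of an at least 1.4-fold lower number from compound 1 to compound 2 (0.15 log units; that floor lies within the scatter); the step of an at least 3.2-fold lower number from compound 1 to compound 3 (0.50 log units; beyond the scatter); and the step of a 2.3-fold lower number from compound 2 to compound 3 (0.35 log units; beyond the scatter).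

Compound 4, `O=C(Nc1ccccc1OC(F)(F)F)N[C@H]1CC[C@H](Oc2ccc(F)cc2)CC1`, keeps the shared core of compound 1 and changes only the aryl group on the urea nitrogen: trifluoromethoxy in place of methylsulfanyl on an aromatic carbon. For the measured compounds named here, none of the measured steps exchanges one ortho group for another while holding that position; the two steps from compound 1 each move the substituent elsewhere on the ring, and the step from compound 2 to compound 3 compares groups at that other place. They do show that leaving the methylsulfanyl arrangement of compound 1 has so far never raised the number, and at best lowered it modestly. The step of an at least 1.3-fold lower number from compound 1 to compound 4 (0.12 log units; that floor lies within the scatter) is therefore expected to be small, in the direction of a lower number, and quite possibly within the scatter. Compound 4 is estimated at 15000 nM, with a range from 5000 nM to 40000 nM in this assay.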

Compound 4, half-maximal inhibitory concentration: > 20000 nM
Compound 4: no number, only a limit; the forecaster's own chance of this, stated with the estimate: 40%; middle value at least 1.3-fold (0.12 log units) from the limit.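

In this assay compound 4 gives > 20000 nM as a limit of the assay and not a number. Compound 1 stands at a limit too, so the step between compound 1 and compound 4 cannot be read: the limit of > 20000 nM in this assay, at which 2 of the 4 values shown sit. The compounds shown leave open whether trifluoromethoxy in place of methylsulfanyl changes the number at all.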